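The compounds below may be only part of what the source reports. "The series", "measured", "known", "first", "only" and "open" are said of these compounds alone.

Among the measured compounds shown here, in a functional assay on Jurkat cells (Homo sapiens) for antiproliferative activity, read by MTT assay, with a stated time of 48 h (a lower number here means a stronger inhibitor, a higher number a weaker inhibitor), compound 1 `O=C(CCCCCCn1cc(Nc2ncc(Cl)c(Nc3cccc(Cl)c3)n2)cn1)NO` gives 100 nM and has only one measured neighbour to compare with. That neighbour is compound 2 `O=C(CCCCCn1cc(Nc2ncc(Cl)c(Nc3cccc(Cl)c3)n2)cn1)NO`, which gives 50 nM in this assay and differs from compound 1 only in the saturated chain that carries the hydroxycarbamoyl group. The step is a 2.0-fold lower number from compound 1 to compound 2 (0.30 log units; within the scatter) and so shows no real difference between the two.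

Compound 3 `O=C(CCCCCCn1cc(Nc2ncc(Cl)c(NC3CC3)n2)cn1)NO` keeps the chain of compound 1 and changes a different group (cyclopropyl in place of 3-chlorophenyl on a nitrogen on an aromatic ring), with cyclopropyl in place of 3-chlorophenyl on a nitrogen on an aromatic ring. For the measured compounds named here, the one measured step concerns the chain alone, and no measured compound varies this group, so the data give no direct guide to the size of this change. Swapping an aromatic ring for a much smaller saturated one is still a substantial edit, so a moderate rise in the number, meaning a weaker inhibitor, is expected, with real uncertainty. The estimated step is a 4.0-fold higher number from compound 1 to compound 3 (0.60 log units; beyond the scatter) and could prove smaller or larger. Starting from the value of compound 1 (100 nM), compound 3 is estimated in this assay at 400 nM (expected range 100 nM to 2000 nM).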

Compound 3, half-maximal inhibitory concentration: 50 nM
The estimate for compound 3 lay 8.0-fold (0.90 log units) above the measured number, outside the stated range (below it).
By their numbers in this assay, from the lowest: compounds 2, 3 and 1 (each within the scatter of the next).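

In this assay, the step is a 2.0-fold lower number from compound 1 to compound 3 (0.30 log units; within the scatter), so cyclopropyl in place of 3-chlorophenyl on a nitrogen on an aromatic ring makes no real difference here. Among the compounds shown here, this is the first information about this position, and it shows that, with the chain of compound 1 in place, a small non-aromatic carbon ring without chlorine can stand where the larger chlorinated aromatic ring stood and the number stays within the scatter. Neither the aromatic character of the group nor its chlorine is therefore required for activity at this level in this pair, though nothing available explains why the two groups read alike.

The compounds shown leave open how far this position can be changed, for example whether a plain phenyl, a larger saturated ring such as cyclohexyl, or an open chain such as methyl or isopropyl would also stay within the scatter. They also leave open whether cyclopropyl behaves the same way on the shorter chain of compound 2, since the chain and this group have so far been varied only separately.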